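The source may report more compounds than this note shows. Statements on the series, on what has been measured and on what is new or still open speak of the compounds shown alone.

Among the measured compounds shown here, compound 1 `CCOC(=O)COn1c(-c2cccc(C#N)c2)nc(C)c1C(=O)OCC` gives 6800 nM in a functional assay on a cell-free system (plasma, Oryctolagus cuniculus) for inhibition, with stated times of 5 min, 1 min and 6 min (on this read-out lower numbers stand for stronger inhibition and higher numbers for weaker inhibition), the highest of the three numbers measured so far, though both neighbours lie within the scatter of it. Compound 2 `CCOC(=O)c1c(C)nc(-c2cccc(C#N)c2)n1OCc1ccncc1` gives 6200 nM, and compound 3 `CCOC(=O)c1c(C)nc(-c2cccc(C#N)c2)n1OCc1ccccc1` gives 5930 nM. The steps of a 1.1-fold lower number from compound 1 to compound 2 (0.04 log units; within the scatter) and a 1.1-fold lower number from compound 1 to compound 3 (0.06 log units; within the scatter) show that exchanging the ethoxycarbonyl for an aromatic ring at this place hardly moved this assay. Compound 4 `CCOC(=O)c1c(C)nc(-c2cccc(C#N)c2)n1OCc1ccc(C#N)cc1` is not yet measured; its change from compound 1 is 4-cyanophenyl in place of ethoxycarbonyl on a saturated chain carbon bound to an oxygen on an aromatic ring, a close relative of the change leading to compound 3. Because the step of a 1.1-fold lower number from compound 1 to compound 3 (0.06 log units; within the scatter) stayed within the scatter, no step beyond the scatter is expected here either, the estimated step being a 1.1-fold lower number from compound 1 to compound 4 (0.05 log units; within the scatter). Compound 4 is therefore expected to give about 6000 nM, most likely between 3000 nM and 12000 nM.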

Compound 4, half-maximal inhibitory concentration: 4240 nM
Beside the measured number, compound 4's estimate is 1.4-fold (0.15 log units) above it; measured number inside the range.
By their numbers in this assay, from the lowest: compounds 4, 3, 2 and 1 (each within the scatter of the next).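

In this assay a substituent on the aromatic ring is new at this position, and adding cyano in place of hydrogen gives a 1.4-fold lower number from compound 3 to compound 4 (0.15 log units; within the scatter) and stays within the usual scatter. The larger exchanges behave alike, with a 1.6-fold lower number from compound 1 to compound 4 (0.21 log units; within the scatter) and a 1.5-fold lower number from compound 2 to compound 4 (0.17 log units; within the scatter) also within it, so the four compounds cannot be told apart here even with the added nitrile. Nothing available explains this result. Still open, on these data alone, is whether an amine or a carboxylic acid in place of the cyano would move the number beyond the scatter.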